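Ethoxy to isopropoxy: the expected step

The source may report more compounds than this note shows. Statements on the series, on what has been measured and on what is new or still open speak of the compounds shown alone.

In a functional assay on A549 cells (Homo sapiens) for antiproliferative activity, read by MTT assay, with a stated time of 48 h (on this read-out higher numbers stand for weaker inhibition and lower numbers for stronger inhibition), compound 1 (`CCOc1cc(-c2ccc3cc[nH]c3c2)cn2c(-c3cc(OC)c(OC)c(OC)c3)nnc12`) gives 626 nM and compound 2 (`CCOc1cc(-c2ccc3c(ccn3C)c2)cn2c(-c3cc(OC)c(OC)c(OC)c3)nnc12`) gives 334 nM in the same test. Among the measured compounds shown here, these two values lie within the scatter of each other, so compound 2 stands level with compound 1 on the only numbers available.

The next structure is compound 3 (`COc1cc(-c2nnc3c(OC(C)C)cc(-c4ccc5c(ccn5C)c4)cn23)cc(OC)c1OC`). The change methyl in place of hydrogen on a saturated chain carbon bound to an oxygen on an aromatic ring and a saturated chain carbon turns the ethoxy group of compound 2 into isopropoxy, with methyl in place of hydrogen on a saturated chain carbon.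

For the measured compounds named here, the single measured step is a 1.9-fold lower number from compound 1 to compound 2 (0.27 log units; within the scatter) and it lies elsewhere in the structure, not at the ethoxy group. The series therefore holds no direct measurement of a change in this chain, and that step offers only weak guidance. No step beyond the scatter is expected, so the estimate stays close to compound 2 at 334 nM in this series.

The expected size is a 1.2-fold higher number from compound 2 to compound 3 (0.08 log units; within the scatter) in this assay on this reading. Compound 3 is estimated at 400 nM with a range from 130 nM to 1200 nM as the expected span.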

Compound 3, half-maximal inhibitory concentration: 322 nM
Compound 3: middle estimate off by 1.2-fold (0.09 log units), on the high side; low and high end bracket the measured number.
By their numbers in this assay, from the lowest: compounds 3, 2 and 1 (each within the scatter of the next).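

In this assay the ethoxy group now has its first direct measured change: turning it into isopropoxy gives a 1.0-fold lower number from compound 2 to compound 3 (0.02 log units; within the scatter). Compound 2 and compound 3 therefore stand level, and one added methyl on a saturated chain carbon bound to an oxygen on an aromatic ring and a saturated chain carbon leaves no readable difference in this test, whereas the earlier step concerned only the indole-bearing part of the structure. No accompanying measurement speaks to why the two compounds stand level.

Going by these compounds, the result rests on a single pair, so the tolerance of this place for other groups remains open: a methoxy group, a free hydroxyl, a longer butoxy chain, or a chain ending in an amine or a carboxylic acid could each hold this level or depart from it. Among the compounds shown here, also open is whether isopropoxy would behave the same way with 1H-indol-6-yl in place of 1-methyl-1H-indol-5-yl, since the two changes appear together in no pair of compounds here.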